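Swapping the dichlorophenyl for methoxyphenyl in compound 1

The source may hold more compounds than are shown below. What is called first, only, known or untested is meant among the compounds shown, and "the series" means these compounds.

Measured compounds:
- compound 1 `Nc1cc(N)c2nc(-c3ccccc3)c(NCc3ccc(Cl)c(Cl)c3)nc2c1`: 19100 nM
- compound 2 `Nc1cc(N)c2nc(-c3ccccc3)c(Sc3ccc(Cl)c(Cl)c3)nc2c1`: < 100000 nM
- compound 3 `CCOC(=O)[C@H](CCC(=O)O)NC(=O)c1ccc(Oc2nc3cc(N)cc(N)c3nc2-c2ccccc2)cc1`: < 50200 nM

Going by the values given here, in a functional assay on PC-3 cells (Homo sapiens) for inhibition, read by sulforhodamine B assay, with a stated time of 48 h (on this read-out higher numbers stand for lower toxicity in this test and lower numbers for higher toxicity in this test), compound 1 gives 19100 nM, the only number in the set. For compound 2 the result is a limit of the assay, < 100000 nM. For compound 3 the result is likewise a limit, < 50200 nM. Among the compounds with values here, both limits are described by the limit of < 100000 nM in this assay, at which 1 of the 3 values shown sits, and (the limit of < 50200 nM in this assay, at which 1 of the 3 values shown sits), so compound 1 is the sole anchor with a real value, and no comparison of measured steps is available.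

Compound 4 `COc1ccc(CNc2nc3cc(N)cc(N)c3nc2-c2ccccc2)cc1` arises from compound 1 by one change: 4-methoxyphenyl in place of 3,4-dichlorophenyl on a saturated chain carbon bound to a nitrogen on an aromatic ring. Within the data shown here, no measured pair shows what such a change does here, so the expected step rests on the structural change alone. I expect a moderate shift toward lower toxicity in this test, with compound 4 estimated at 35000 nM and a range from 12000 nM to 100000 nM, which corresponds to an expected step of a 1.8-fold higher number from compound 1 to compound 4 (0.26 log units; within the scatter).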

Compound 4, concentration lethal to 50% of the cells: 72400 nM
Compound 4: middle estimate off by 2.1-fold (0.32 log units), on the low side; the range from low to high includes it.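

In this assay, going by these compounds alone, the swap gives a 3.8-fold higher number from compound 1 to compound 4 (0.58 log units; beyond the scatter) and so provides the first measured comparison in this set, pointing toward lower toxicity in this test. The swap keeps a six-membered aromatic ring of carbon and the same number of heavy atoms, yet the number still moves beyond the usual scatter, so the groups on this saturated chain carbon are not interchangeable here. Nothing measured here explains why the number moves.

This single pair cannot separate the effect of losing the two chlorines from that of adding the methoxy group, and a plain phenyl or a ring with one chlorine at this place would help to tell them apart. Within the data shown here, compound 2 and compound 3 each have only a limit, so no step involving them can be read.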